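Compound 2 to compound 3 at the assay limit

The source may hold more compounds than are shown below. What is called first, only, known or untested is meant among the compounds shown, and "the series" means these compounds.

Measured in an ADME assay on HEK293 cells (Homo sapiens) for cytotoxicity, read by reporter gene assay and resazurin assay, with a stated time of 48 h; a lower number here means that less compound is tolerated, a higher number that more compound is tolerated:
- compound 1 `O=C(Nc1ccc(Sc2nc3ccccc3s2)c(Cl)c1)c1cc(Br)cc(Br)c1`: > 100000 nM (a limit)
- compound 2 `COc1ccccc1C(=O)Nc1ccc(Sc2nc3ccccc3s2)c(Cl)c1`: > 100000 nM (a limit)

For the measured compounds named here, compound 2 has only a limit and no number, and the one other value is also a limit: both sit at the limit of > 100000 nM in this assay, at which 2 of the 2 values shown sit. The next compound is compound 3 `O=C(Nc1ccc(Sc2nc3ccccc3s2)c(Cl)c1)c1cc(Br)ccc1O`, with 5-bromo-2-hydroxyphenyl in place of 2-methoxyphenyl on a carbonyl carbon. Going by the values given here, the only measured step that bears on this is a step that the two limits leave unreadable from compound 1 to compound 2, and it gives no size to carry over. Compound 1 carries bromine on the ring at this place and gives > 100000 nM, which is a limit. Among the compounds with values here, no compound with a hydroxy group on this ring has been measured, so the expectation in this assay is weakly grounded. A move to a lower number is expected, though compound 3 may well report only a limit again. The expected change is an at least 5.0-fold lower number from compound 2 to compound 3 (0.69 log units; beyond the scatter). Compound 3 is estimated at 20000 nM, with an expected range of 2000 nM to 100000 nM.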

Compound 3, half-maximal cytotoxic concentration: 45000 nM
Compound 3: middle estimate off by 2.3-fold (0.35 log units), on the low side; the measured number falls inside the stated range.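

In this assay, for the compounds shown here, 5-bromo-2-hydroxyphenyl in place of 2-methoxyphenyl on a carbonyl carbon gives an at least 2.2-fold lower number from compound 2 to compound 3 (0.34 log units; beyond the scatter), the first readable step at this position. The same group in place of 3,5-dibromophenyl gives an at least 2.2-fold lower number from compound 1 to compound 3 (0.34 log units; beyond the scatter), so carrying bromine on this ring does not by itself set the outcome, and among the three compounds only the ring with a hydrogen-bond donor brings the reading to a number. The step between compound 1 and compound 2 cannot be read, and the two new steps are bounds rather than sizes, because both starting compounds sit at a limit: the limit of > 100000 nM in this assay, at which 2 of the 3 values shown sit.

Compound 3 differs from compound 2 in both the hydroxy group and the bromine, and the compounds shown do not separate the share of each in the step. On these data alone, how an amine or a carboxylic acid in place of the hydroxy group would read in this assay also stays open.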